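From bromine to nitrile on the phenyl ring

The source may hold more compounds than are shown below. What is called first, only, known or untested is meant among the compounds shown, and "the series" means these compounds.

Measured compounds:
compound 1, `CC(=O)/N=C1\NC2(CCCCO2)CCS1`, 3.1 mg/kg
compound 2, `O=C(/N=C1\NC2(CCCCO2)CCS1)c1ccccc1`, 5 mg/kg
compound 3, `O=C(/N=C1\NC2(CCCCO2)CCS1)c1ccc(Br)cc1`, > 200 mg/kg

All three were tested in a functional assay on the whole organism (strain CF-1) with Mus musculus as the target, in the writhing test, with a stated time of 15 min; a lower number here means that less compound is needed, a higher number that more compound is needed for the effect. Compound 1 gives 3.1 mg/kg, and the step of a 1.6-fold higher number from compound 1 to compound 2 (0.21 log units; within the scatter) shows that putting a phenyl on the carbonyl carbon changes little. Compound 3 sits at the limit of > 200 mg/kg in this assay, at which 1 of the 3 values shown sits, which is a limit of the assay and not a number, so its true place among these compounds is unknown beyond being at or past that limit. The step of an at least 40-fold higher number from compound 2 to compound 3 (1.60 log units; beyond the scatter) is large.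

Compound 4 `N#Cc1ccc(C(=O)/N=C2\NC3(CCCCO3)CCS2)cc1` differs from compound 3 by cyano in place of bromo on an aromatic carbon. Within the data shown here, no measured step exchanges one group for another on that aromatic carbon; the only step touching that carbon is an at least 40-fold higher number from compound 2 to compound 3 (1.60 log units; beyond the scatter), in which adding bromo cost a great deal. Whether cyano acts like bromo or like hydrogen there cannot be read from these three compounds. Compound 4 is therefore expected to remain weak, with a fair chance of another limit, and the expected step is an at least 1.3-fold lower number from compound 3 to compound 4 (0.12 log units; that floor lies within the scatter). The estimate for compound 4 is 150 mg/kg, ranging from 20 mg/kg to 400 mg/kg.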

Compound 4, dose for half-maximal effect: 60 mg/kg
Beside the measured number, compound 4's estimate is 2.5-fold (0.40 log units) above it; low and high end bracket the measured number.
By their numbers in this assay, from the lowest: compounds 1 and 2 (each within the scatter of the next); then compound 4. At a limit, above all of these: compound 3.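

Among these compounds, exchanging bromo for cyano gives the first measured swap of one group for another on this aromatic carbon, and in this assay it brings a clear gain: an at least 3.3-fold lower number from compound 3 to compound 4 (0.52 log units; beyond the scatter). Compound 3 stands at a limit and not at a number, so this step is only a floor: the limit of > 200 mg/kg in this assay, at which 1 of the 4 values shown sits.

Cyano still does not return to what plain hydrogen gives, with a 12-fold higher number from compound 2 to compound 4 (1.08 log units; beyond the scatter), so both groups shown on this carbon stand well above hydrogen, and they are not equally costly.

On these data alone, whether an amine or a methoxy group on this same carbon would stay close to hydrogen or climb as cyano and bromo do remains open. What lies behind the rise also stays open, as no property of these groups is measured here.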